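This account rests on a few compounds, and the source may have more. Where it says the series, first, only, none or still open, it means among the compounds named here.

Measured compounds:
- compound 1, `COc1cc(Cl)cc(-c2nn(-c3cccc(NC(=O)Nc4ccc(Cl)c(Cl)c4)c3)cc2-c2ccncc2)c1`: 9.24%
- compound 2, `COc1cc(Cl)cc(-c2nn(-c3cccc(NC(=O)c4cccc(C(F)(F)F)c4)c3)cc2-c2ccncc2)c1`: 51.7%
- compound 3, `O=C(Nc1cccc(-n2cc(-c3ccncc3)c(-c3cc(O)cc(Cl)c3)n2)c1)c1cc(C(F)(F)F)cc(C(F)(F)F)c1`: 10.5%

In a functional assay on LOX IMVI cells (Homo sapiens) for inhibition, read by sulforhodamine B assay, with a stated time of 48 h, tested at 10 uM (on this read-out lower numbers stand for a stronger effect and higher numbers for a weaker effect at the one concentration tested), compound 3 gives 10.5%, the second highest of the three numbers. Its nearest neighbour is compound 1, whose value of 9.24% lies within the scatter of compound 3; furthest away is compound 2, whose 51.7% sits beyond the scatter above compound 3.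

Compound 4, `COc1cc(Cl)cc(-c2nn(-c3cccc(NC(=O)c4cc(C(F)(F)F)cc(C(F)(F)F)c4)c3)cc2-c2ccncc2)c1`, differs from compound 3 in one place: methyl in place of hydrogen on an oxygen on an aromatic ring. Going by the values given here, none of the measured steps touches this position. Among the compounds with values here, the only step between compounds differing in one place, a number 42.5 percentage points higher from compound 1 to compound 2 (beyond the scatter), concerns the group on the carbonyl carbon and not the oxygen on the aromatic ring, so it offers no direct guide. Compound 2 does carry the methoxy group and shows a higher number than compound 3, but it also differs in the group on the carbonyl, so its value alone cannot be assigned to the methyl. Within the data shown here, with no step bearing on the change, the expectation for a number 9.5 percentage points higher from compound 3 to compound 4 (within the scatter) is a step that stays within the scatter, with the uncertainty leaning upward. Compound 4 is therefore estimated at 20% in this assay, within a range of 4% to 55%.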

Compound 4, a percentage reported as activity, at one concentration (the size of the read-out at that concentration, not a potency): 76.1%
Estimate against measurement, compound 4: 56.1 percentage points below; the whole stated range lies below it.
By their numbers in this assay, from the lowest: compounds 1 and 3 (each within the scatter of the next); then compound 2; then compound 4.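

In this assay, the oxygen on the aromatic ring turns out to be a highly sensitive position: going from hydroxy to methoxy, a change of one carbon, gives a number 65.6 percentage points higher from compound 3 to compound 4 (beyond the scatter), so within this pair the free hydroxy goes with the far stronger effect at the one concentration tested. With methoxy in place, the group on the carbonyl also matters, for trifluoromethyl in place of hydrogen on an aromatic carbon gives a number 24.4 percentage points higher from compound 2 to compound 4 (beyond the scatter), and methoxy alone does not set a weak effect, since compound 1 carries it too and gives 9.24%. Nothing in the information available explains why this small change has so large an effect.

The compounds shown leave open whether the large step is specific to hydroxy and methoxy, or whether an ethoxy chain, an amine or a carboxylic acid at this place would sit nearer compound 3 or compound 4. Going by these compounds alone, they also leave open whether the hydroxy would bring a similar step alongside the urea of compound 1 or the single trifluoromethyl of compound 2.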